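Methoxy for chloro on the aryl of compound 2

The source may hold more compounds than are shown below. What is called first, only, known or untested is meant among the compounds shown, and "the series" means these compounds.

Two compounds of this series have been run in a functional assay on the whole organism (strain BALB/c) for inhibition, with Mus musculus as the target, in the writhing test, with stated times of 1 h and 10 min, at a dose of 100 mg/kg by the oral route; on this read-out higher numbers stand for more inhibition at the one dose given (going by the name of the read-out) and lower numbers for less inhibition. Compound 1 `Sc1n[nH]c(-c2ccccc2)n1` gives 35.9%. Compound 2 `CCOC(=O)Cc1csc2nc(-c3ccc(Cl)cc3)nn12` gives 38.5%. The two numbers sit within the usual scatter of each other, so neither compound can be set above the other on the data in hand; compound 2 stands alongside compound 1, and nothing more can be said of its place.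

Compound 3 `CCOC(=O)Cc1csc2nc(-c3ccc(OC)cc3)nn12` has not been measured. It differs from compound 2 in one place: methoxy in place of chloro on an aromatic carbon. Going by the values given here, no pair of measured compounds shows what such a change does in this assay, so no direction can be read from the series itself. The change is expected to be small, neither clearly up nor clearly down, estimated as a number 2.5 percentage points lower from compound 2 to compound 3 (within the scatter). Compound 3 is accordingly expected to give about 36% in this assay, with a range from 20% to 52%.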

Compound 3, a percentage reported as inhibition, in the whole organism at one dose (the size of the read-out at that dose, not a potency): 24.3%
For compound 3 the middle estimate is 11.7 percentage points above the measured one, and the stated range covers the measured number.
By their numbers in this assay, from the lowest: compound 3; then compounds 1 and 2 (each within the scatter of the next).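

Methoxy in place of chloro on an aromatic carbon, para to a large group, gives a number 14.2 percentage points lower from compound 2 to compound 3 (beyond the scatter) in this assay. Going by these compounds alone, this is the only one-place step so far, and it shows that the read-out responds to the group at this position. Of the two groups compared here, chloro gives the higher inhibition at the one dose given, and nothing on hand accounts for the difference.

From the compounds shown here alone, it remains open whether this step is specific to methoxy or whether other replacements for chloro, such as fluoro, an amine or a longer alkoxy chain, would give a similar number. The compounds shown also leave open how the ethyl ester side of the molecule bears on the read-out, for instance with a carboxylic acid or an amide in its place.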